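Ester variations on the furan dihydropyrimidinone core

The source may hold more compounds than are shown below. What is called first, only, known or untested is meant among the compounds shown, and "the series" means these compounds.

Measured so far in an assay on membranes from HEK293 cells for displacement of a labelled ligand from adenosine receptor A2b (Homo sapiens), read by scintillation counting, with a stated time of 30 min; a lower number here means a stronger inhibitor, a higher number a weaker inhibitor:
compound 1 `CC1=C(C(=O)OCC(C)C)C(c2ccoc2)NC(=O)N1`, 326 nM
compound 2 `CC1=C(C(=O)OC(C)(C)C)C(c2ccoc2)NC(=O)N1`, 4440 nM
compound 3 `CC1=C(C(=O)OCc2ccccc2)C(c2ccoc2)NC(=O)N1`, 6650 nM

Compound 2 stands second highest of the three numbers; its nearest neighbour is compound 3, with a 1.5-fold higher number from compound 2 to compound 3 (0.18 log units; within the scatter), and the furthest is compound 1, where a 14-fold higher number from compound 1 to compound 2 (1.13 log units; beyond the scatter).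

Compound 4 `CC1=C(C(=O)CC(C)C)C(c2ccoc2)NC(=O)N1` differs from compound 2 by isobutyl in place of tert-butoxy on a carbonyl carbon. The two large measured steps, a 14-fold higher number from compound 1 to compound 2 (1.13 log units; beyond the scatter) and a 20-fold higher number from compound 1 to compound 3 (1.31 log units; beyond the scatter), both change only the group on the oxygen and show that the shape of that group moves the number strongly. Among the compounds with values here, no measured step removes the oxygen itself, so the change to compound 4 has no direct precedent in this assay. Compound 4 carries the same isobutyl chain as compound 1, which gives 326 nM, but on a different atom, and the tert-butoxy of compound 2 is gone. The number for compound 4 is therefore expected to move, most likely downward from compound 2, by a 2.2-fold lower number from compound 2 to compound 4 (0.35 log units; beyond the scatter), with wide uncertainty. The estimate for compound 4 in this assay is 2000 nM, in a range from 400 nM to 10000 nM.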

Compound 4, inhibition constant: 1010 nM
Compound 4: middle estimate off by 2.0-fold (0.30 log units), on the high side; measured number inside the range.
By their numbers in this assay, from the lowest: compound 1; then compound 4; then compounds 2 and 3 (each within the scatter of the next).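

With the isobutyl chain held constant, the first direct read on the ester oxygen in this assay is a 3.1-fold higher number from compound 1 to compound 4 (0.49 log units; beyond the scatter), so losing that oxygen costs affinity, though less than the change of chain shape in a 14-fold higher number from compound 1 to compound 2 (1.13 log units; beyond the scatter). Compound 4 nevertheless keeps a lower number than the tert-butyl ester, with a 4.4-fold lower number from compound 2 to compound 4 (0.64 log units; beyond the scatter); this step changes the chain and removes the oxygen at once, so it cannot separate the two contributions. No supporting data bear on why the oxygen matters here.

Still open, from the compounds shown here alone, is whether an amide nitrogen carrying the same isobutyl chain, in place of the oxygen or the methylene, would fall nearer compound 1 or compound 4. Also open, going by these compounds, is how a longer chain or a cyclopentyl group on the carbonyl carbon would compare with the isobutyl of compound 4.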